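Trading a Cyclopentyl Ring for an Isopropyl Group

The compounds below may be only part of what the source reports. "The series", "measured", "known", "first", "only" and "open" are said of these compounds alone.

Compound 1 `Nc1cc(C2CCCC2)nc2ccc(NC(=O)/C=C/c3ccc(C(F)(F)F)cc3)cc12` carries a cyclopentyl group on the aromatic carbon next to the ring nitrogen of its shared core. In a functional assay on HEK293 cells for activation of melanin-concentrating hormone receptor 1 (Homo sapiens), read by inositol phosphate accumulation (a lower number here means that less compound is needed, a higher number that more compound is needed for the effect), compound 1 gives 68 nM, the lowest number among the three measured compounds. Compound 3 `CCCc1cc(N)c2cc(NC(=O)/C=C/c3ccc(C(C)C)cc3)ccc2n1` gives 520 nM and compound 2 `CCCc1cc(N2CCCC2)c2cc(NC(=O)/C=C/c3ccc(C(F)(F)F)cc3)ccc2n1` gives 2800 nM; both lie beyond the scatter above compound 1, but each differs from it in more than one place, so no single change can be read from them. Compound 4 `CC(C)c1cc(N)c2cc(NC(=O)/C=C/c3ccc(C(F)(F)F)cc3)ccc2n1` applies one change to compound 1: isopropyl in place of cyclopentyl on an aromatic carbon. Within the data shown here, no measured pair isolates this change. A modest rise in the number is expected, as the step from compound 1 to compound 4 a 2.2-fold higher number from compound 1 to compound 4 (0.34 log units; beyond the scatter). Compound 4 is therefore estimated at 150 nM, within a range from 50 nM to 500 nM.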

Compound 4, half-maximal effective concentration: 160 nM
Compound 4: the middle estimate sits 1.1-fold (0.03 log units) below what was measured; the range from low to high includes it.
By their numbers in this assay, from the lowest: compound 1; then compound 4; then compound 3; then compound 2.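

Among these compounds, this is the first step at this position that can be read on its own: with the rest of compound 1 held fixed, isopropyl in place of cyclopentyl gives a 2.4-fold higher number from compound 1 to compound 4 (0.37 log units; beyond the scatter) and lies beyond the usual scatter. The five-membered ring is therefore not required for activation, although replacing it costs a modest step.

On these data alone, the ring and the atom count change together here, so whether a methyl group or a cyclohexyl ring would move the number further remains open. No measurement shown explains the rise.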